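The source may report more compounds than this note shows. Statements on the series, on what has been measured and on what is new or still open speak of the compounds shown alone.

Within the data shown here, compound 1 `NS(=O)(=O)CC(=O)NCCSc1nonc1/C(=N/O)Nc1cccc(Br)c1` is one of two compounds measured so far in this set. In an assay for inhibition of Indoleamine 2,3-dioxygenase 1 (Homo sapiens), read by fluorescence, with a stated time of 24 h (a higher number here means a weaker inhibitor, a lower number a stronger inhibitor), compound 1 gives 8.1 nM, the lower of the two numbers recorded. Compound 2 `CSc1nonc1/C(=N/O)Nc1ccc(F)c(Br)c1` gives 15 nM in this assay, a number that lies within the scatter of the value for compound 1, so the two cannot be put in order.

Compound 3 `NS(=O)(=O)CC(=O)NCCSc1nonc1/C(=N/O)Nc1ccc(F)c(C(F)F)c1` has not yet been measured. It departs from compound 1 by a single change: 3-(difluoromethyl)-4-fluorophenyl in place of 3-bromophenyl on an amine nitrogen. Among the measured compounds shown here, no measured pair in this set shows that change, so nothing here tells its size directly. The estimated step of a 1.5-fold higher number from compound 1 to compound 3 (0.17 log units; within the scatter) is expected to be small and not clearly beyond the scatter in either direction. Compound 3 is therefore expected to give 12 nM in this assay, with a range from 4 nM to 40 nM.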

Compound 3, half-maximal inhibitory concentration: 13 nM
Compound 3: middle estimate off by 1.1-fold (0.03 log units), on the low side, and the stated range covers the measured number.
By their numbers in this assay, from the lowest: compounds 1, 3 and 2 (each within the scatter of the next).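

In this assay, among these compounds, the step of a 1.6-fold higher number from compound 1 to compound 3 (0.21 log units; within the scatter) is the first direct comparison at the amine nitrogen, with the rest of compound 1 held unchanged. It shows that, at this position, 3-(difluoromethyl)-4-fluorophenyl can replace 3-bromophenyl without a difference that this assay can separate from the scatter, even though the bromine is lost and the entering group has more heavy atoms. Nothing available here explains why the two groups give such similar numbers.

Among the compounds shown here, the single exchange leaves open how the difluoromethyl group and the fluorine each contribute, since they enter together. On these data alone, it also remains open whether a ring carrying a nitrile, an amine or a carboxylic acid at this position would stay within the scatter of compound 1.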